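A (thiophen-2-yl)sulfonyl in place of 4-fluorobenzyl

This account rests on a few compounds, and the source may have more. Where it says the series, first, only, none or still open, it means among the compounds named here.

Among the compounds with values here, in a functional assay on HeLa cells (Homo sapiens) for antiproliferative activity, read by MTT assay, with a stated time of 48 h (on this read-out lower numbers stand for stronger inhibition and higher numbers for weaker inhibition), compound 2 (`Cn1cc(-c2cnc3ccc(NCc4ccc(F)cc4)nc3c2)cn1`) gives 46600 nM, the only exact number so far. Compound 1 (`CC(=O)Nc1ccc2ncc(-c3cnn(C)c3)cc2n1`) is reported only as a limit of the assay, > 50000 nM. Evidence on this pair is thin, as it rests on (the limit of > 50000 nM in this assay, at which 1 of the 2 values shown sits).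

Compound 3 (`Cn1cc(-c2cnc3ccc(NS(=O)(=O)c4cccs4)nc3c2)cn1`) keeps the core of compound 2 and changes one group: (thiophen-2-yl)sulfonyl in place of 4-fluorobenzyl on a nitrogen on an aromatic ring. In words, (thiophen-2-yl)sulfonyl stands in place of 4-fluorobenzyl on a nitrogen on an aromatic ring.

Within the data shown here, the one measured exchange on that nitrogen, an at least 1.0-fold lower number from compound 1 to compound 2 (0.03 log units; that floor lies within the scatter), stays within the scatter, so it offers no precedent for a large move. No step beyond the scatter is therefore expected in this assay. The expected change is a 1.3-fold lower number from compound 2 to compound 3 (0.12 log units; within the scatter). For compound 3 the estimate is 35000 nM, with an expected range from 8000 nM to 50000 nM.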

Compound 3, half-maximal inhibitory concentration: 38400 nM
For compound 3 the middle estimate is 1.1-fold (0.04 log units) below the measured one; measured number inside the range.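

In this assay, replacing a six-membered carbon ring on a benzyl link with a five-membered ring holding a hetero atom on a sulfonyl link, which brings hydrogen-bond acceptors with it, leaves the number in place: a 1.2-fold lower number from compound 2 to compound 3 (0.08 log units; within the scatter). Within the data shown here, this gives the first exchange on this nitrogen with exact numbers at both ends, and it too stays within the scatter. The comparison with the acetyl compound gives only a floor, also within the scatter, an at least 1.3-fold lower number from compound 1 to compound 3 (0.11 log units; that floor lies within the scatter), and how far that step really reaches cannot be told: the limit of > 50000 nM in this assay, at which 1 of the 3 values shown sits.

Going by these compounds, what an amine, a carboxylic acid or a longer chain on this nitrogen would do stays open. So does whether any group at this place, or any change to the shared core, can move the number beyond the scatter.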